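This account rests on a few compounds, and the source may have more. Where it says the series, first, only, none or still open, it means among the compounds named here.

Measured so far:
Compound 1 `COc1cccc(/C=N/c2ccc(OCc3ccccc3)cc2)c1O`: in a functional assay, with a stated time of 30 min (a higher number here means a weaker inhibitor, a lower number a stronger inhibitor), compound 1 gives only a limit, > 200000 nM.
Compound 2 `O=[N+]([O-])c1ccc(O)c(/C=N/c2ccc(OCc3ccccc3)cc2)c1`: in this assay compound 2 likewise gives only a limit, > 200000 nM.

Compound 2 thus stands at the limit of this assay, with no number of its own; (the limit of > 200000 nM in this assay, at which 2 of the 2 values shown sit). Compound 3 `Cc1ccc(O)c(/C=N/c2ccc(OCc3ccccc3)cc2)c1` carries methyl in place of nitro on an aromatic carbon. Among the compounds with values here, no measured pair differing in one place exists, so no step size can be read from the data. In this assay the estimated step is a number no higher from compound 2 to compound 3 (the limit leaves the size open), expected not to exceed the usual scatter. For compound 3 the expected value is 200000 nM, with a range from 50000 nM to 800000 nM, most likely reported again only as a limit.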

Compound 3, half-maximal inhibitory concentration: > 200000 nM
Compound 3 gave a limit, no number (the forecaster's own chance of this, stated with the estimate: 85%); the middle value sits exactly at the limit.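

Within the data shown here, compound 2 and compound 3 both give only a limit in this assay and no step between them can be read. The compounds shown leave open whether any change on the shared core brings this assay to a readable number.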